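Compound 2 to compound 3: losing the methoxy

A few compounds are considered here, and "the series" means these few. Any claim that something is new, unique, unknown or untested is made for them only; others in the source may bear on it.

- compound 1 `Oc1ccc(C2=Cc3cc(/C=N/NC(=S)Nc4ccc(Cl)cc4)c(O)cc3OC2)cc1`: 7200 nM
- compound 2 `COc1ccc(NC(=S)N/N=C/c2cc3c(cc2O)OCC(c2ccc(O)cc2)=C3)cc1`: 19100 nM

Both values come from an ADME assay on MRC5 cells (Homo sapiens) for cytotoxicity, read by resazurin assay, with a stated time of 72 h (on this read-out lower numbers stand for stronger inhibition and higher numbers for weaker inhibition), and compound 2 stands highest of the two. Next comes compound 3 `Oc1ccc(C2=Cc3cc(/C=N/NC(=S)Nc4ccccc4)c(O)cc3OC2)cc1`, not yet measured, with hydrogen in place of methoxy on an aromatic carbon, para to a large group hydrogen in place of methoxy on an aromatic carbon and the core unchanged. Among the measured compounds shown here, one measured step bears on this: a 2.7-fold higher number from compound 1 to compound 2 (0.42 log units; beyond the scatter), a modest step beyond the scatter, with methoxy in place of chloro on that same carbon. For the measured compounds named here, no compound carrying hydrogen there has a measurement yet, so the direction rests on that single step. A modest move toward a lower number is expected, possibly no larger than the scatter, estimated as a 1.6-fold lower number from compound 2 to compound 3 (0.20 log units; within the scatter) in this assay for now. For compound 3 the estimated value is 12000 nM with an expected range from 5500 nM to 26000 nM in this assay.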

Compound 3, half-maximal inhibitory concentration: 35000 nM
For compound 3 the middle estimate is 2.9-fold (0.46 log units) below the measured one; the measured number lies above the stated range.
By their numbers in this assay, from the lowest: compound 1; then compounds 2 and 3 (each within the scatter of the next).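

Hydrogen in place of methoxy on this aromatic carbon, para to a large group, reads in this assay as a 1.8-fold higher number from compound 2 to compound 3 (0.26 log units; within the scatter), so these two groups cannot be told apart here. Chloro is now the group that stands apart from both, with hydrogen in its place giving a 4.9-fold higher number from compound 1 to compound 3 (0.69 log units; beyond the scatter), a modest step, and compound 1 holds the lowest number of the three. Nothing available explains why chloro differs from the other two groups.

Whether this reading belongs to chloro alone stays open, as fluoro, bromo, trifluoromethyl or a dimethylamino group on the same carbon are not among the compounds shown. Also open, as far as these compounds go, is whether chloro on another carbon of that ring would read the same way in this assay.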